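This account rests on a few compounds, and the source may have more. Where it says the series, first, only, none or still open, it means among the compounds named here.

Compound 1 `Cc1ccc2ncc(S(=O)(=O)c3ccc(F)cc3)c(N3CCC(C)CC3)c2c1`: 90%
Compound 2 `Cc1ccc2ncc(S(=O)(=O)c3cc(F)cc(F)c3)c(N3CCC(C)CC3)c2c1`: 72%

Among the compounds with values here, in an assay on isolated protein for displacement of a labelled ligand from metabotropic glutamate receptor 5 (Homo sapiens), with a stated time of 60 min, tested at 1 uM (a higher number here means more inhibition at the concentration tested (going by the name of the read-out), a lower number less inhibition), compound 1 gives 90% and compound 2 gives 72%, so compound 2 stands lowest of the two numbers known. Compound 3 `Cc1ccc2ncc(S(=O)(=O)c3ccccc3)c(N3CCC(C)CC3)c2c1` is not yet measured; it differs from compound 2 in one place: phenyl in place of 3,5-difluorophenyl on a sulfonyl sulfur. Within the data shown here, the only measured step that bears on this change is a number 18 percentage points lower from compound 1 to compound 2 (beyond the scatter), a modest loss on going from 4-fluorophenyl to 3,5-difluorophenyl. Taking both fluorines away is expected to recover most of that ground, and the expected step is a number 12 percentage points higher from compound 2 to compound 3 (beyond the scatter). Compound 3 is therefore estimated at 84%, with a range from 70% to 95%.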

Compound 3, a percentage reported as inhibition, at one concentration (the size of the read-out at that concentration, not a potency): 67%
Beside the measured number, compound 3's estimate is 17 percentage points above it; the whole stated range lies above it.
By their numbers in this assay, from the lowest: compounds 3 and 2 (each within the scatter of the next); then compound 1.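

On the aryl group at the sulfonyl sulfur, this assay gives a number 5 percentage points lower from compound 2 to compound 3 (within the scatter) and so does not tell phenyl from 3,5-difluorophenyl. The fluoro of compound 1 does count, since hydrogen in its place on the aromatic carbon gives a number 23 percentage points lower from compound 1 to compound 3 (beyond the scatter) and leaves compound 1 as the only one of the three that separates from the others. Nothing measured here bears on the reason for this. On these data alone, whether a chloro or a methoxy group in place of that fluoro would hold the number of compound 1 stays open.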